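A few compounds are considered here, and "the series" means these few. Any claim that something is new, unique, unknown or untested is made for them only; others in the source may bear on it.

Measured compounds

Compound 1, `Cc1ccc(S(=O)(=O)Oc2ccc3c(c2C)[C@H](Cn2cc(-c4ccccc4)nn2)[C@@]24CC(=O)[C@@](C)(CC[C@@H]32)C4)cc1`: in a functional assay on HL-60 cells (Homo sapiens) for cytotoxicity, read by MTT assay, with a stated time of 4 days (a lower number here means a stronger inhibitor, a higher number a weaker inhibitor), compound 1 gives > 20000 nM, which is a limit of the assay and not a number.

Compound 2, `C=C1C[C@]23C[C@@]1(O)CC[C@@H]2c1cccc(C)c1[C@@H]3Cn1cc(-c2ccc(Cl)cc2)nn1`: in this assay compound 2 gives > 20000 nM, again a limit of the assay rather than a number.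

Where compound 2 stands: only a limit is known for it, and the other value in the set is a limit too. For the measured compounds named here, this is summed up by the limit of > 20000 nM in this assay, at which 2 of the 2 values shown sit, so no step between measured compounds can be sized, and no order between compound 1 and compound 2 can be read from the numbers.

Compound 3, `C=C1C[C@]23C[C@@]1(O)CC[C@@H]2c1cccc(C)c1[C@@H]3Cn1cc(-c2ccccn2)nn1`, is not yet measured. It differs from compound 2 by pyridin-2-yl in place of 4-chlorophenyl on an aromatic carbon. Going by the values given here, with no measured step to lean on, the expected change in this assay is a step that the limit leaves unreadable from compound 2 to compound 3, none beyond the scatter, with the result most likely remaining a limit. For compound 3 the estimate in this assay is 25000 nM, with a range from 8000 nM to 80000 nM.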

Compound 3, half-maximal inhibitory concentration: > 20000 nM
Compound 3 ended at the assay's limit; the forecaster's own chance of this, stated with the estimate: 80%; the middle value lies beyond the limit too.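

No step can be read from compound 2 to compound 3 in this assay, since both results are limits of the assay and not numbers: the limit of > 20000 nM in this assay, at which 3 of the 3 values shown sit.

The compounds shown leave open whether any change on the shared core gives a measurable value in this assay.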